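The compounds below may be only part of what the source reports. "The series", "measured", "known", "first", "only" and "open" are said of these compounds alone.

Measured so far in a functional assay on KG-1 cells (Homo sapiens) for cytotoxicity, read by luminescence and CellTiter-Glo, with a stated time of 3 days; a lower number here means a stronger inhibitor, a higher number a weaker inhibitor:
Compound 1 `N#Cc1ccc(NC(=O)c2cc(C(F)(F)F)ccc2O)cc1`: 4810 nM
Compound 2 `N#Cc1ccc(NC(=O)c2ccccc2O)cc1`: 5370 nM

Among the measured compounds shown here, compound 2 lies within the scatter of compound 1, the only other measured compound, so no order between them can be drawn. Compound 3 `Cc1ccc(O)c(C(=O)Nc2ccc(C#N)cc2)c1` differs from compound 2 by methyl in place of hydrogen on an aromatic carbon. For the measured compounds named here, the one measured change at that same carbon, hydrogen in place of trifluoromethyl, gave a 1.1-fold higher number from compound 1 to compound 2 (0.05 log units; within the scatter), so no step beyond the scatter is expected in this assay. The expected change is a 1.1-fold lower number from compound 2 to compound 3 (0.03 log units; within the scatter). Compound 3 is estimated at 5000 nM, with an expected range of 2500 nM to 10000 nM.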

Compound 3, half-maximal inhibitory concentration: 3370 nM
Compound 3: the middle estimate sits 1.5-fold (0.17 log units) above what was measured; low and high end bracket the measured number.
By their numbers in this assay, from the lowest: compounds 3, 1 and 2 (each within the scatter of the next).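

In this assay, methyl in place of hydrogen at this carbon, para to a hydroxy group, gives a small step (a 1.6-fold lower number from compound 2 to compound 3 (0.20 log units; within the scatter)), and methyl in place of trifluoromethyl gives another (a 1.4-fold lower number from compound 1 to compound 3 (0.15 log units; within the scatter)). With both steps within the scatter, hydrogen, methyl and trifluoromethyl at this carbon cannot be told apart, so three groups of different size now leave the number unmoved. No measured evidence bears on this result.

Going by these compounds, whether an amine, a carboxylic acid or a longer chain at this carbon would move the number beyond the scatter stays open.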